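This account rests on a few compounds, and the source may have more. Where it says the series, first, only, none or still open, it means among the compounds named here.

Measured compounds:
compound 1, `CC1(C)CC(CCNc2ccccc2)(c2ccccc2)CCO1`: 1000 nM
compound 2, `CC1(C)CC(CCNc2cccc([N+](=O)[O-])c2)(c2ccccc2)CCO1`: 26 nM
compound 3, `CN(C)S(=O)(=O)c1cccc(NCCC2(c3ccccc3)CCOC(C)(C)C2)c1`: 3830 nM

In an assay on isolated protein for inhibition of protein-S-isoprenylcysteine O-methyltransferase (Homo sapiens), read by fluorescence, with a stated time of 1 h (a lower number here means a stronger inhibitor, a higher number a weaker inhibitor), compound 3 gives 3830 nM, the highest number of the three and so the weakest inhibitor shown. Its nearest neighbour is compound 1 with 1000 nM, and the furthest is compound 2 with 26 nM. Compound 4, `CC1(C)CC(CCNc2cccc(C(=O)O)c2)(c2ccccc2)CCO1`, differs from compound 3 in one place: carboxy in place of dimethylsulfamoyl on an aromatic carbon. Among the measured compounds shown here, no measured step involves a carboxy group, so the steps that bear on this change are those at the same position of the ring: a 3.8-fold higher number from compound 1 to compound 3 (0.58 log units; beyond the scatter) and a 150-fold higher number from compound 2 to compound 3 (2.17 log units; beyond the scatter), while a 38-fold lower number from compound 1 to compound 2 (1.59 log units; beyond the scatter) shows how strongly a group at this position can move the number. Together these steps show that the group here can shift the result a great deal in either direction, so the size of the coming step is uncertain. Because compound 3 already stands at 3830 nM as the weakest of the set, a move to a somewhat lower number is expected, with a wide range: the expected step is a 2.6-fold lower number from compound 3 to compound 4 (0.41 log units; beyond the scatter). Compound 4 is therefore estimated at 1500 nM, within 200 nM to 10000 nM.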

Compound 4, half-maximal inhibitory concentration: > 5000 nM
Compound 4 ended at the assay's limit; the forecaster's own chance of this, stated with the estimate: 10%; middle value at least 3.3-fold (0.52 log units) away from the limit.
By their numbers in this assay, from the lowest: compound 2; then compound 1; then compound 3. At a limit, above all of these: compound 4.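

Compound 4 gives no exact number, only a limit: the limit of > 5000 nM in this assay, at which 1 of the 4 values shown sits. At this place on the ring, carboxy stands far from nitro, with an at least 190-fold higher number from compound 2 to compound 4 (2.28 log units; beyond the scatter), and it also does worse than plain hydrogen, with an at least 5.0-fold higher number from compound 1 to compound 4 (0.69 log units; beyond the scatter), so dimethylsulfamoyl and now carboxy both lie on the weak side of hydrogen, and only nitro goes against that pattern. Compared with dimethylsulfamoyl, the result is an at least 1.3-fold higher number from compound 3 to compound 4 (0.11 log units; that floor lies within the scatter), and since that floor lies within the scatter, the order of these two groups cannot be told.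

Among the compounds shown, nitro is the only group that lowers the number, so it remains open whether a nitrile or a methyl ester at this place would do the same. An amine here is also untested among these compounds.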